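The compounds below may be only part of what the source reports. "The series", "measured", "known", "first", "only" and "open" are said of these compounds alone.

Measured so far in a functional assay on HCT-15 cells (Homo sapiens) for inhibition, read by sulforhodamine B assay, with a stated time of 48 h, tested at 10 uM; on this read-out lower numbers stand for less inhibition and higher numbers for more inhibition at the one concentration tested (going by the name of the read-out):
compound 1 `Fc1ccc(-c2cn3ccnc3c(-c3ccc4ncn(C5CCCCC5)c4c3)n2)cc1` gives 7.59%;
compound 2 `c1cn2cc(-c3ccsc3)nc(-c3ccc4ncn(C5CCCCC5)c4c3)c2n1` gives 1.37%.

Compound 2 stands at the lowest of the two numbers, and compound 1 is its nearest neighbour. Among the measured compounds shown here, the only measured step between them, a number 6.2 percentage points lower from compound 1 to compound 2 (within the scatter), lies within the scatter, so both compounds show only slight inhibition at the one concentration tested. Compound 3 `Clc1ccc(-c2cn3ccnc3c(-c3ccc4ncn(C5CCCCC5)c4c3)n2)cc1` has not yet been measured. It differs from compound 2 in one place: 4-chlorophenyl in place of thiophen-3-yl on an aromatic carbon. The measured step that bears on this change is the exchange of the group at the same place, a number 6.2 percentage points lower from compound 1 to compound 2 (within the scatter), which was within the scatter. On that basis no step beyond the scatter is expected for compound 3 in this assay, in neither direction. Compound 3 is accordingly estimated to give 5%, with a range from -5% to 20%. The expected step for this change is a number 3.6 percentage points higher from compound 2 to compound 3 (within the scatter).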

Compound 3, a percentage reported as inhibition, at one concentration (the size of the read-out at that concentration, not a potency): 15.5%
The estimate for compound 3 lay 10.5 percentage points below the measured number; low and high end bracket the measured number.
By their numbers in this assay, from the lowest: compounds 2, 1 and 3 (each within the scatter of the next, the first and the last beyond it).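

In this assay, among the compounds shown here, the exchange at this aromatic carbon gives a step beyond the scatter for the first time: with 4-chlorophenyl in place of thiophen-3-yl, the result is a number 14.1 percentage points higher from compound 2 to compound 3 (beyond the scatter), so the group at this place can move the read-out, though only modestly. Chloro in place of fluoro on the same phenyl ring gives a number 7.9 percentage points higher from compound 1 to compound 3 (within the scatter), so this exchange of halogens cannot be told apart from repeat variation. No available data bear on why the 4-chlorophenyl and thiophen-3-yl compounds differ.

From the compounds shown here alone, it remains open how a plain phenyl, or a phenyl ring carrying an amine or a carboxylic acid, would read at this place. With only one concentration tested, the potency of these compounds also remains open.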